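Swapping pyridin-4-yl for thiophen-2-yl on a shared core

This account rests on a few compounds, and the source may have more. Where it says the series, first, only, none or still open, it means among the compounds named here.

Four compounds share one core, each carrying a 3-hydroxyphenyl group and a chlorophenyl group on a six-membered aromatic ring with one nitrogen. Compound 1 `Oc1cccc(-c2cc(-c3ccncc3)nc(-c3ccccc3Cl)c2)c1` has its chlorine placed as a 2-chlorophenyl group, compound 2 `Oc1cccc(-c2cc(-c3ccncc3)nc(-c3cccc(Cl)c3)c2)c1` as a 3-chlorophenyl group, and compound 3 `Oc1cccc(-c2cc(-c3ccncc3)nc(-c3ccc(Cl)cc3)c2)c1` as a 4-chlorophenyl group. In a functional assay on HCT-15 cells (Homo sapiens) for cytotoxicity, read by CCK-8 assay and cell counting, with a stated time of 2 days (on this read-out higher numbers stand for weaker inhibition and lower numbers for stronger inhibition), compound 3 gives 2630 nM. In this assay, going by the values given here, compound 1 gives "not determined" (no result reported), and compound 2 gives "not determined" (no result reported), so compound 1 stands without a number of its own, and compound 3 carries the only measured value.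

Compound 4 `Oc1cccc(-c2cc(-c3cccs3)nc(-c3ccccc3Cl)c2)c1` is the unmeasured partner of compound 1. The change is thiophen-2-yl in place of pyridin-4-yl on an aromatic carbon, placed on an aromatic carbon next to the ring nitrogen, meta to the 2-chlorophenyl group and meta to the 3-hydroxyphenyl group. Among the compounds with values here, since compound 1 has no value, no step can be computed, and nothing among the measured compounds shows what the exchange of one aromatic ring for another does here; no particular direction is expected in this assay, and a change beyond the scatter would be as plausible as none at all. Taking compound 3 with its 2630 nM as the only anchor, compound 4 is expected to give about 3000 nM in this assay, with a wide range from 500 nM to 20000 nM.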

Compound 4, half-maximal inhibitory concentration: 2790 nM
Beside the measured number, compound 4's estimate is 1.1-fold (0.03 log units) above it, and the stated range covers the measured number.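

No step can be read between compound 1 and compound 4 in this assay, as only compound 4 has a single number there. The compounds shown leave open what exchanging pyridin-4-yl for thiophen-2-yl does to the value on this shared core. Nothing at hand offers an explanation for the result of compound 4.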